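A new ring on the sulfonamide nitrogen of compound 2

The source may report more compounds than this note shows. Statements on the series, on what has been measured and on what is new or still open speak of the compounds shown alone.

For the measured compounds named here, in a physicochemical assay for solubility (on this read-out higher numbers stand for higher solubility and lower numbers for lower solubility), compound 2 `Cn1nccc1-c1cc(C(F)(F)F)ccc1[C@H]1CCOc2cc(S(=O)(=O)Nc3nccs3)ccc21` gives 83000 nM and stands highest of the two numbers so far, with compound 1 `Cc1nc(-c2cc(C(F)(F)F)ccc2[C@H]2CCOc3cc(S(=O)(=O)Nc4cccc(F)n4)ccc32)co1` at 13000 nM lower by more than the scatter. Compound 3 `Cn1nccc1-c1cc(C(F)(F)F)ccc1[C@H]1CCOc2cc(S(=O)(=O)Nc3cccc(F)n3)ccc21` has 6-fluoropyridin-2-yl in place of 1,3-thiazol-2-yl on a sulfonamide nitrogen and is otherwise unchanged. Going by the values given here, no measured pair isolates this change. Compound 1 also carries 6-fluoropyridin-2-yl there and gives 13000 nM on a different core, so a lower number is expected in this assay. The estimated step of a 3.0-fold lower number from compound 2 to compound 3 (0.47 log units; beyond the scatter) would lie beyond the scatter. The estimate for compound 3 is 28000 nM with 10000 nM to 70000 nM as its expected range.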

Compound 3, solubility: 27000 nM
The estimate for compound 3 lay 1.0-fold (0.02 log units) above the measured number, within the range that was stated.
By their numbers in this assay, from the lowest: compound 1; then compound 3; then compound 2.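

In this assay, the shared core now gives a direct reading of 6-fluoropyridin-2-yl in place of 1,3-thiazol-2-yl on a sulfonamide nitrogen: a 3.1-fold lower number from compound 2 to compound 3 (0.49 log units; beyond the scatter), a modest step beyond the scatter. Compound 3 also isolates a second change, 1-methyl-1H-pyrazol-5-yl in place of 2-methyl-1,3-oxazol-4-yl on an aromatic carbon, with a 2.1-fold higher number from compound 1 to compound 3 (0.32 log units; beyond the scatter), also modest. Nothing measured here explains either step. The compounds shown leave open how a plain phenyl or a pyrimidin-2-yl ring on that sulfonamide nitrogen would read. They also leave open whether 1,3-thiazol-2-yl would give a similar step alongside 2-methyl-1,3-oxazol-4-yl.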